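The compounds below may be only part of what the source reports. "The series", "measured", "known", "first", "only" and "open" are said of these compounds alone.

Measured so far:
- Compound 1, `Cc1nc(S(C)(=O)=O)ccc1Oc1ncnc(OC2CCN(C(=O)OC3(C(F)(F)F)CCC3)CC2)c1F`: in a functional assay on isolated protein for inhibition of Glucose-dependent insulinotropic receptor (Rattus norvegicus), read by HTRF and cAMP accumulation (on this read-out higher numbers stand for an effect only at larger amounts of compound and lower numbers for an effect already at smaller amounts), compound 1 gives 63.3 nM.
- Compound 2, `Cc1nc(S(C)(=O)=O)ccc1Oc1ncnc(OC2CCN(C(=O)C(C)(F)F)CC2)c1F`: in this assay compound 2 gives 239 nM.

For the measured compounds named here, compound 2 has the higher of the two numbers; the only neighbour is compound 1, and the step of a 3.8-fold higher number from compound 1 to compound 2 (0.58 log units; beyond the scatter) separates them. Compound 3, `Cc1nc(S(C)(=O)=O)ccc1Oc1ncnc(OC2CCN(C(=O)c3nc(C(C)(C)F)no3)CC2)c1F`, is not yet measured. It differs from compound 2 in this way: a group of 9 heavy atoms (5 carbon, 2 nitrogen, 1 oxygen, 1 fluorine; one five-membered aromatic ring with 3 hetero atoms) in place of a group of 4 heavy atoms (2 carbon, 2 fluorine; no ring), on a carbonyl carbon. Going by the values given here, this bears on the one measured step, a 3.8-fold higher number from compound 1 to compound 2 (0.58 log units; beyond the scatter), in which a small group on the carbonyl carbon took the place of a large group with a ring and the number rose by a modest amount. Going from compound 2 to compound 3 puts a large group with a ring back in that place, so a modest step in the opposite direction is expected in this assay, about the size of a 3.0-fold lower number from compound 2 to compound 3 (0.48 log units; beyond the scatter). Compound 3 is therefore estimated at 80 nM, within a range from 25 nM to 250 nM.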

Compound 3, half-maximal effective concentration: 606 nM
For compound 3 the middle estimate is 7.6-fold (0.88 log units) below the measured one; the whole stated range lies below it.
By their numbers in this assay, from the lowest: compound 1; then compound 2; then compound 3.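

At this place on the carbonyl carbon, a larger group with a ring does not by itself lower the number in this assay: the change gives a 2.5-fold higher number from compound 2 to compound 3 (0.40 log units; beyond the scatter), even though the earlier step, a 3.8-fold higher number from compound 1 to compound 2 (0.58 log units; beyond the scatter), went with a smaller group. Two groups of equal heavy-atom count also differ here, with a 9.6-fold higher number from compound 1 to compound 3 (0.98 log units; beyond the scatter), so the count alone does not set the number at this place. Nothing measured here explains either difference.

The compounds shown leave open whether the five-membered aromatic ring or the fluorine on its side chain accounts for the higher number. A plain methyl on that ring, or a simple amine on the carbonyl carbon, would extend the comparison to groups not yet represented.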